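The source may hold more compounds than are shown below. What is called first, only, known or untested is meant among the compounds shown, and "the series" means these compounds.

Measured in a functional assay on KBVIN cells (Homo sapiens) for antiproliferative activity, read by sulforhodamine B assay, with a stated time of 3 days (on this read-out higher numbers stand for weaker inhibition of growth and lower numbers for stronger inhibition of growth), so far

Compound 1 (`COc1ccc(N2CCN(C)CC2)cc1Nc1ncc(F)c(Nc2ccc(F)cc2)n1`) gives 910 nM
Compound 2 (`O=C(Nc1ccc(C(F)(F)F)cc1)c1cccc(Nc2ncc(F)c(Nc3ccc(F)cc3)n2)c1`) gives > 10000 nM (a limit, not a number)

Compound 2 has no exact value, only a limit: the data show the limit of > 10000 nM in this assay, at which 1 of the 2 values shown sits, and compound 2 is that one value. Compound 3 (`O=C(c1cccc(Nc2ncc(F)c(Nc3ccc(F)cc3)n2)c1)N1CCCCC1`) has not yet been measured. It carries piperidin-1-yl in place of (4-(trifluoromethyl)phenyl)amino on a carbonyl carbon and is otherwise the same as compound 2. A six-membered non-aromatic ring therefore replaces a six-membered aromatic ring of carbon only, and the amide hydrogen is lost.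

Within the data shown here, no measured pair of compounds differs in just one place, so the data give no direct guide to the size of this change. Compound 1 differs from compound 2 in more than one place and offers no clean comparison. The expectation therefore rests on compound 2 and its limit (> 10000 nM), and growth inhibition is expected to stay weak. The expected change, an at least 1.1-fold lower number from compound 2 to compound 3 (0.04 log units; that floor lies within the scatter) in this assay, is small, towards slightly stronger inhibition if it can be seen at all. Compound 3 is estimated at 9000 nM (expected range 3000 nM to 30000 nM).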

Compound 3, concentration for 50% growth inhibition: 13800 nM
Estimate against measurement, compound 3: 1.5-fold (0.19 log units) below; low and high end bracket the measured number.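

The step from compound 2 to compound 3 cannot be read, because compound 2 has only a limit and not a number: the limit of > 10000 nM in this assay, at which 1 of the 3 values shown sits. The compounds shown leave open how far piperidin-1-yl in place of (4-(trifluoromethyl)phenyl)amino on a carbonyl carbon changes growth inhibition, and in which direction.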